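Removing the nitrogen methyl from compound 2

This account rests on a few compounds, and the source may have more. Where it says the series, first, only, none or still open, it means among the compounds named here.

In a functional assay on CCRF-CEM cells (Homo sapiens) (on this read-out higher numbers stand for lower toxicity in this test and lower numbers for higher toxicity in this test), compound 2 (`Cc1cn([C@@H]2O[C@H](CO[Si](C)(C)C(C)(C)C)[C@@]3(OS(=O)(=O)C(I)=C3N)[C@H]2O[Si](C)(C)C(C)(C)C)c(=O)n(C)c1=O`) gives the lowest number of the three at 5600 nM so far. Compound 1 (`Cc1cn([C@@H]2O[C@H](CO[Si](C)(C)C(C)(C)C)[C@@]3(OS(=O)(=O)C(Br)=C3N)[C@H]2O[Si](C)(C)C(C)(C)C)c(=O)[nH]c1=O`) with 17000 nM and compound 3 (`C=CCC1=C(N)[C@@]2(OS1(=O)=O)[C@@H](CO[Si](C)(C)C(C)(C)C)O[C@@H](n1cc(C)c(=O)n(C)c1=O)[C@@H]2O[Si](C)(C)C(C)(C)C`) with 45000 nM both give higher numbers. Compound 4 (`Cc1cn([C@@H]2O[C@H](CO[Si](C)(C)C(C)(C)C)[C@@]3(OS(=O)(=O)C(I)=C3N)[C@H]2O[Si](C)(C)C(C)(C)C)c(=O)[nH]c1=O`) arises from compound 2 by hydrogen in place of methyl on an aromatic nitrogen with hydrogen in place of methyl on an aromatic nitrogen. Among the measured compounds shown here, no measured step isolates this change. The only one, an 8.0-fold higher number from compound 2 to compound 3 (0.91 log units; beyond the scatter), sits at a double-bonded ring carbon and gives scale only. Compound 1 also carries hydrogen on that nitrogen, and its 17000 nM suggests a small move toward higher numbers in this assay rather than a large one. The expected step is a 1.6-fold higher number from compound 2 to compound 4 (0.21 log units; within the scatter) and should stay small. Compound 4 is estimated at 9000 nM with a range from 3500 nM to 25000 nM for now.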

Compound 4, half-maximal cytotoxic concentration: 4000 nM
Estimate against measurement, compound 4: 2.3-fold (0.35 log units) above; the range from low to high includes it.
By their numbers in this assay, from the lowest: compounds 4 and 2 (each within the scatter of the next); then compound 1; then compound 3.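

In this assay the position on the aromatic nitrogen is now read alone: a 1.4-fold lower number from compound 2 to compound 4 (0.15 log units; within the scatter) shows that hydrogen in place of methyl there stays within the scatter. Among the compounds shown here, the iodo in place of bromo change is also isolated for the first time, with a 4.3-fold lower number from compound 1 to compound 4 (0.63 log units; beyond the scatter) giving a step beyond the scatter on the double-bonded ring carbon. Nothing measured here offers a reason for either step.

As far as these compounds go, whether the iodo and bromo step holds with methyl on the aromatic nitrogen remains open. Also open, from the compounds shown here alone, is how a longer chain such as propyl, or a carboxylic acid, would read at that nitrogen.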